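Replacing the ureido group in compound 2

The source may hold more compounds than are shown below. What is called first, only, known or untested is meant among the compounds shown, and "the series" means these compounds.

In an ADME assay for permeability, using PAMPA, with a stated time of 4 h, at pH 5.5 (on this read-out lower numbers stand for lower permeability and higher numbers for higher permeability), compound 1 (`NC/C=C/CN(C[C@H]1Cc2ncccc2CN1)[C@H]1CCCc2cccnc21`) gives 2 nm/s while compound 2 (`NC(=O)NCCCCN(C[C@H]1Cc2ncccc2CN1)[C@H]1CCCc2cccnc21`) gives 7 nm/s and compound 3 (`NC(=O)NC/C=C\CN(C[C@H]1Cc2ncccc2CN1)[C@H]1CCCc2cccnc21`) gives 5 nm/s. Compound 2 thus stands with compound 3 at the upper end of these numbers, and a 1.4-fold lower number from compound 2 to compound 3 (0.15 log units; within the scatter) stays within the scatter. Compound 4 (`c1cnc2c(c1)CN[C@@H](CN(CCCCN(C1COC1)C1COC1)[C@H]1CCCc3cccnc31)C2`) carries the change (a group of 9 heavy atoms (6 carbon, 1 nitrogen, 2 oxygen; 2 four-membered non-aromatic rings with 1 hetero atom each) in place of a group of 4 heavy atoms (1 carbon, 2 nitrogen, 1 oxygen; no ring), on a saturated chain carbon, four bonds along the chain from an amine nitrogen). Among the measured compounds shown here, no measured step covers this exchange. The nearest guides to size are the modest 3.5-fold higher number from compound 1 to compound 2 (0.54 log units; beyond the scatter) and a 2.5-fold higher number from compound 1 to compound 3 (0.40 log units; beyond the scatter), so only a modest shift is expected, with the upward direction a tentative call. The expected step is a 2.0-fold higher number from compound 2 to compound 4 (0.30 log units; within the scatter) in this assay. For compound 4 the estimated value is 14 nm/s (expected range 4 nm/s to 50 nm/s).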

Compound 4, apparent permeability: 62 nm/s
For compound 4 the middle estimate is 4.4-fold (0.65 log units) below the measured one, outside the stated range (above it).
By their numbers in this assay, from the lowest: compound 1; then compounds 3 and 2 (each within the scatter of the next); then compound 4.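

At this place, on a saturated chain carbon, four bonds along the chain from an amine nitrogen, the ureido group can be exchanged for a group with 2 four-membered non-aromatic rings: in this assay the exchange gives an 8.9-fold higher number from compound 2 to compound 4 (0.95 log units; beyond the scatter) and is the largest listed step in the series. The entering group has 0 hydrogen-bond donors and 3 hydrogen-bond acceptors, but this one step cannot separate those counts from the added rings. Nothing at hand bears on the origin of this rise.

Open, as far as these compounds go, is whether a dimethylamino group or a morpholine at this place would give a similar step. Also open, from the compounds shown here alone, is whether the same group on the unsaturated chain of compound 3 would behave alike.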